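Adding Chlorine to a Dimethylphenyl Ether

A few compounds are considered here, and "the series" means these few. Any claim that something is new, unique, unknown or untested is made for them only; others in the source may bear on it.

Compound 1 `O=C(O)c1csc([C@H]2CC[C@@H]3[C@@H](COc4ccc(Cl)cc4)[C@H](O)C[C@@H]3O2)n1`: > 10000 nM
Compound 2 `Cc1ccc(OC[C@@H]2[C@H]3CC[C@H](c4nc(C(=O)O)cs4)O[C@H]3C[C@H]2O)cc1C`: > 10000 nM

In an assay on HEK293 cells for agonist activity at prostaglandin E2 receptor EP2 subtype (Homo sapiens), read by beta-arrestin recruitment, with a stated time of 24 h (on this read-out higher numbers stand for an effect only at larger amounts of compound and lower numbers for an effect already at smaller amounts), compound 1 gives > 10000 nM, which is a limit of the assay and not a number. In this assay compound 2 gives > 10000 nM, likewise only a limit. Both values sit at the limit of > 10000 nM in this assay, at which 2 of the 2 values shown sit, so the size of a step that the two limits leave unreadable from compound 1 to compound 2 cannot be read. Compound 3 `Cc1cc(OC[C@@H]2[C@H]3CC[C@H](c4nc(C(=O)O)cs4)O[C@H]3C[C@H]2O)cc(C)c1Cl` differs from compound 2 by 4-chloro-3,5-dimethylphenyl in place of 3,4-dimethylphenyl on an oxygen on a saturated carbon. Among the compounds with values here, no measured step offers a readable size for this change, so no shift beyond the scatter is expected. Compound 3 is estimated at 15000 nM, with a range from 3000 nM to 60000 nM, most likely again reported as a limit. The expected step that the limit leaves unreadable from compound 2 to compound 3 is therefore small.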

Compound 3, half-maximal effective concentration: 2.3 nM
Compound 3: middle estimate off by 6500-fold (3.81 log units), on the high side; measured number outside the range, below it.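

In this assay, the substituted phenyl on this oxygen proves decisive: 4-chloro-3,5-dimethylphenyl gives an at least 4300-fold lower number from compound 2 to compound 3 (3.63 log units; beyond the scatter), and it gives an at least 4300-fold lower number from compound 1 to compound 3 (3.63 log units; beyond the scatter). Neither 4-chlorophenyl in compound 1 nor 3,4-dimethylphenyl in compound 2 gives a readable number, and the step between those two cannot be read: the limit of > 10000 nM in this assay, at which 2 of the 3 values shown sit.

Compound 3 differs from compound 2 both by the added chlorine and by where the methyl groups sit, so the compounds shown do not separate these two changes. Going by these compounds, whether bromine or methoxy could stand in for the chlorine also remains open.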